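A few compounds are considered here, and "the series" means these few. Any claim that something is new, unique, unknown or untested is made for them only; others in the source may bear on it.

In an ADME assay on MT4 cells (Homo sapiens) for cytotoxicity, read by MTT assay (on this read-out lower numbers stand for higher toxicity in this test and higher numbers for lower toxicity in this test), compound 1 `O=C1c2ccccc2C(=O)N1CCOC(=S)N(C(=O)c1ccccc1[N+](=O)[O-])c1ccc(Cl)cc1` gives 21000 nM. Compound 2 `O=C1c2ccccc2C(=O)N1CCOC(=S)N(C(=O)c1ccc([N+](=O)[O-])cc1)c1ccc(Cl)cc1` reaches only the assay limit, > 100000 nM. Compound 3 `O=C1c2ccccc2C(=O)N1CCOC(=S)N(C(=O)c1ccc(F)cc1F)c1ccc(Cl)cc1` gives 52000 nM.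

Compound 1 thus stands lowest of the two numbers shown; its nearest neighbour is compound 3, reached through a 2.5-fold higher number from compound 1 to compound 3 (0.39 log units; beyond the scatter). The further value of compound 2 is a limit (the limit of > 100000 nM in this assay, at which 1 of the 3 values shown sits). Compound 4 `O=C1c2ccccc2C(=O)N1CCOC(=S)N(C(=O)c1ccc(Cl)c([N+](=O)[O-])c1)c1ccc(Cl)cc1` differs from compound 1 by 4-chloro-3-nitrophenyl in place of 2-nitrophenyl on a carbonyl carbon. Within the data shown here, two measured steps bear on this move away from 2-nitrophenyl: an at least 4.7-fold higher number from compound 1 to compound 2 (0.67 log units; beyond the scatter) and a 2.5-fold higher number from compound 1 to compound 3 (0.39 log units; beyond the scatter). Both point to a higher number, so a modest rise in this assay is expected for compound 4, as a 2.6-fold higher number from compound 1 to compound 4 (0.42 log units; beyond the scatter). Compound 4 is therefore estimated at 55000 nM, with a range from 22000 nM to 130000 nM.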

Compound 4, half-maximal cytotoxic concentration: 48000 nM
Compound 4: middle estimate off by 1.1-fold (0.06 log units), on the high side, within the range that was stated.
By their numbers in this assay, from the lowest: compound 1; then compounds 4 and 3 (each within the scatter of the next). At a limit, above all of these: compound 2.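

In this assay, 4-chloro-3-nitrophenyl on the carbonyl carbon still gives a modest rise over 2-nitrophenyl, with a 2.3-fold higher number from compound 1 to compound 4 (0.36 log units; beyond the scatter), but it does not reach 4-nitrophenyl, with an at least 2.0-fold lower number from compound 2 to compound 4 (0.31 log units; beyond the scatter). Compound 2 stands at a limit of the assay, so that step gives only a floor: the limit of > 100000 nM in this assay, at which 1 of the 4 values shown sits. With a 1.1-fold lower number from compound 3 to compound 4 (0.03 log units; within the scatter), 4-chloro-3-nitrophenyl and 2,4-difluorophenyl cannot be told apart here. The compounds shown leave open how far compound 2 truly lies from compound 4, and what an aminophenyl or a carboxyphenyl on this carbonyl carbon would give in this assay.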